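The source may hold more compounds than are shown below. What is called first, only, known or untested is meant among the compounds shown, and "the series" means these compounds.

Measured in a functional assay on MCF7 cells (Homo sapiens) for antiproliferative activity, read by MTT assay, with a stated time of 72 h; on this read-out lower numbers stand for stronger inhibition and higher numbers for weaker inhibition:
- Compound 1 `CC/C=C/C(=O)Nc1cccc(Oc2nc(Nc3ccn(C)n3)nc3c2CSCC3)c1`: > 50000 nM (a limit of the assay, not a number)
- Compound 2 `C=CC(=O)Nc1cccc(Oc2nc(Nc3cccc(C#N)c3)nc3c2CSCC3)c1`: 21700 nM
- Compound 3 `C/C=C/C(=O)Nc1cccc(Oc2nc(Nc3cccc(C#N)c3)nc3c2CSCC3)c1`: 21400 nM

Only compound 2 and compound 3 have actual numbers in this assay, and the two stand level within the scatter. Compound 1 gives only a limit, > 50000 nM, so it offers no number for comparison.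

Compound 4 `CC/C=C/C(=O)Nc1cccc(Oc2nc(Nc3cccc(C#N)c3)nc3c2CSCC3)c1` is the next point to read. It differs from compound 3 by methyl in place of hydrogen on a saturated chain carbon bound to a double-bonded chain carbon. In words, this is methyl in place of hydrogen on a saturated chain carbon bound to a double-bonded chain carbon, which turns prop-1-en-1-yl into but-1-en-1-yl on the carbonyl.

Among the compounds with values here, one measured step bears on this change: prop-1-en-1-yl in place of vinyl on a carbonyl carbon, a 1.0-fold lower number from compound 2 to compound 3 (0.01 log units; within the scatter). That step also adds a single carbon to the same chain and produced no shift beyond the scatter. Within the data shown here, it is only one step, so it is a thin basis for the expectation. The expected step is a 1.1-fold higher number from compound 3 to compound 4 (0.03 log units; within the scatter), with no movement in either direction beyond the scatter.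

The estimated value for compound 4 is 23000 nM, with an expected range of 12000 nM to 45000 nM.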

Compound 4, half-maximal inhibitory concentration: 15900 nM
Compound 4: middle estimate off by 1.4-fold (0.16 log units), on the high side; low and high end bracket the measured number.
By their numbers in this assay, from the lowest: compounds 4, 3 and 2 (each within the scatter of the next). At a limit, above all of these: compound 1.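

Working from this assay, the extra carbon on this chain, methyl in place of hydrogen on a saturated chain carbon bound to a double-bonded chain carbon, gives a 1.3-fold lower number from compound 3 to compound 4 (0.13 log units; within the scatter), and the full change from vinyl to but-1-en-1-yl on the carbonyl gives a 1.4-fold lower number from compound 2 to compound 4 (0.14 log units; within the scatter). Compounds 2, 3 and 4 therefore show that, from vinyl through prop-1-en-1-yl to but-1-en-1-yl, this chain has not moved the number beyond the scatter, and none of the three goes against that reading. The one step beyond the scatter comes from a different place, 3-cyanophenyl in place of 1-methyl-1H-pyrazol-3-yl on a nitrogen on an aromatic ring, at an at least 3.1-fold lower number from compound 1 to compound 4 (0.49 log units; beyond the scatter), and its size is only a bound, as compound 1 gives a limit of the assay and not a number: the limit of > 50000 nM in this assay, at which 1 of the 4 values shown sits.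

Open, going by these compounds, is whether a longer chain, a branched chain or a terminal dimethylamino group on the but-1-en-1-yl chain would shift the number beyond the scatter in this assay. Also open, on these data alone, is whether a carboxylic acid or an amine in place of the nitrile would keep the gain seen with 3-cyanophenyl.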